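This account rests on a few compounds, and the source may have more. Where it says the series, first, only, none or still open, it means among the compounds named here.

Values so far in a functional assay on HeLa cells (Homo sapiens) for antiproliferative activity, read by MTT assay, with a stated time of 48 h; on this read-out higher numbers stand for weaker inhibition and lower numbers for stronger inhibition
compound 1 `COc1ccc2c(/C=C/C(=O)c3cc(OC)c(OC)c(SC)c3)c[nH]c2c1` at 131 nM
compound 2 `COc1ccc2c(/C=C/C(=O)c3cc(OC)c(OC)c([N+](=O)[O-])c3)c[nH]c2c1` at 850 nM
compound 3 `COc1cc(C(=O)/C=C/c2c[nH]c3ccccc23)cc([N+](=O)[O-])c1OC` at 1350 nM

Compound 3 lies within the scatter of compound 2, and the two share the high end of these three numbers, clearly above compound 1. The next structure is compound 4 `COc1cc(C(=O)/C=C/c2c[nH]c3ccccc23)cc(SC)c1OC` with methylsulfanyl in place of nitro on an aromatic carbon, ortho to a methoxy group. The counted change is methylsulfanyl in place of nitro on an aromatic carbon and nothing else in the structure differs.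

The same exchange has been measured once, in the opposite sense, as a 6.5-fold higher number from compound 1 to compound 2 (0.81 log units; beyond the scatter) for nitro in place of methylsulfanyl on an aromatic carbon. The other measured step, a 1.6-fold higher number from compound 2 to compound 3 (0.20 log units; within the scatter) for hydrogen in place of methoxy on an aromatic carbon, stays within the scatter, so the missing methoxy of compound 3 gives no measured reason to discount that exchange here. A single pair is thin evidence, so the range is kept wide. Reversing the exchange, the expected result in this assay is a 6.4-fold lower number from compound 3 to compound 4 (0.81 log units; beyond the scatter) and this would lie beyond the scatter. Compound 4 is estimated at 210 nM with an expected range from 90 nM to 480 nM in this read-out.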

Compound 4, half-maximal inhibitory concentration: 159 nM
Beside the measured number, compound 4's estimate is 1.3-fold (0.12 log units) above it; the range from low to high includes it.
By their numbers in this assay, from the lowest: compounds 1 and 4 (each within the scatter of the next); then compounds 2 and 3 (each within the scatter of the next).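

In this assay, the exchange of nitro for methylsulfanyl, at the position ortho to a methoxy group, now reads on a second core, as an 8.5-fold lower number from compound 3 to compound 4 (0.93 log units; beyond the scatter), and the two readings agree: the same change on two cores in this assay, a 6.5-fold higher number (0.81 log units; beyond the scatter) from compound 1 to compound 2 and an 8.5-fold higher number (0.93 log units; beyond the scatter) from compound 4 to compound 3, 1.3-fold (0.12 log units) apart, within the scatter of two such steps

The methoxy difference between the two cores, previously seen only with nitro at this position, now also reads with methylsulfanyl there, as a 1.2-fold higher number from compound 1 to compound 4 (0.08 log units; within the scatter), and it stays within the scatter with both groups: the same change on two cores in this assay, a 1.6-fold higher number (0.20 log units; within the scatter) from compound 2 to compound 3 and a 1.2-fold higher number (0.08 log units; within the scatter) from compound 1 to compound 4, 1.3-fold (0.12 log units) apart, within the scatter of two such steps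

Across these four compounds, with none going against it, the numbers separate by the group at this position and not by the presence of that methoxy group on the core.

The compounds shown leave open how an amine, a hydroxyl group or a longer chain such as ethylsulfanyl would read at this position, where nitro and methylsulfanyl are the only groups shown. They also leave open whether the sulfur atom is needed for the lower numbers, which a plain methyl or ethyl group there would begin to separate.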